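An amino group leaves compound 2

The compounds below may be only part of what the source reports. "The series", "measured", "known", "first", "only" and "open" are said of these compounds alone.

Compound 1 `C=C1[C@@H](O)[C@H](n2cnc3c(Cl)nc(N)nc32)O[C@@H]1CO` and compound 2 `C=C1[C@@H](O)[C@H](n2cnc3c(N)nc(N)nc32)O[C@@H]1CO` share one core and differ at a single aromatic carbon. In a functional assay on MT4 cells (Homo sapiens) for inhibition (a higher number here means a weaker inhibitor, a lower number a stronger inhibitor), compound 1 gives > 500000 nM, which is a limit and not a number. In this assay compound 2 gives > 200000 nM, which is also a limit. Compound 3 `C=C1[C@@H](O)[C@H](n2cnc3c(N)ncnc32)O[C@@H]1CO` differs from compound 2 by hydrogen in place of amino on an aromatic carbon, between two ring nitrogen atoms: hydrogen in place of amino on an aromatic carbon. Going by the values given here, the only measured comparison is a step that the two limits leave unreadable from compound 1 to compound 2, so no step beyond the scatter can be expected in this assay, in either direction. The expected change is a step that the limit leaves unreadable from compound 2 to compound 3. For compound 3 the estimate is 300000 nM, with an expected range of 60000 nM to 1000000 nM, and the assay may well report only a limit again.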

Compound 3, half-maximal inhibitory concentration: 43000 nM
For compound 3 the middle estimate is 7.0-fold (0.84 log units) above the measured one; measured number below the stated range.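

Hydrogen in place of amino on this aromatic carbon, between two ring nitrogen atoms, gives the first readable change in the series, an at least 4.6-fold lower number from compound 2 to compound 3 (0.66 log units; beyond the scatter) in this assay. This shows that the position matters and that losing the amino group moves the compound towards stronger inhibition, whereas the step from chloro to amino on a different aromatic carbon of the shared core cannot be read. The full size of the new step stays unknown because compound 2 gives only a limit and not a number: the limit of > 200000 nM in this assay, at which 1 of the 3 values shown sits.

The compounds shown leave open whether a methyl group or a hydroxyl group on this carbon would behave like hydrogen or like amino. They also leave open whether hydrogen here would give a similar change with chloro in place of the remaining amino group.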